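This account rests on a few compounds, and the source may have more. Where it says the series, first, only, none or still open, it means among the compounds named here.

Compound 1 `Cn1cc(C2=C(c3nn(CCCn4cccc4)c4ncccc34)C(=O)NC2=O)c2ccccc21` is tested in a functional assay on ECa-109 cells (Homo sapiens) for antiproliferative activity, read by MTT assay, with a stated time of 48 h (on this read-out higher numbers stand for weaker inhibition and lower numbers for stronger inhibition), and gives > 100000 nM, which is a limit of the assay and not a number. It therefore stands at the limit of > 100000 nM in this assay, at which 1 of the 2 values shown sits. Compound 2 `Cn1cc(C2=C(c3nn(CCCN4CCCCC4)c4ncccc34)C(=O)N(c3ccccn3)C2=O)c2ccccc21`, which carries different groups, gives a true number in this assay, 7300 nM. The next compound, compound 3 `Cn1cc(C2=C(c3nn(CCCCn4ccnc4)c4ncccc34)C(=O)NC2=O)c2ccccc21`, keeps the unsubstituted imide of compound 1 and changes only the side chain: (1H-imidazol-1-yl)methyl in place of 1H-pyrrol-1-yl on a saturated chain carbon, three bonds along the chain from an aromatic nitrogen. In words, (1H-imidazol-1-yl)methyl replaces 1H-pyrrol-1-yl on a saturated chain carbon, three bonds along the chain from an aromatic nitrogen. Among the measured compounds shown here, no measured step bears on this change, so only a modest gain in strength is expected in this assay, and the reading may well stay at the limit. The expected step, an at least 2.0-fold lower number from compound 1 to compound 3 (0.30 log units; that floor lies within the scatter), is an estimate measured from a limit. For compound 3 the estimated value is 50000 nM, with an expected range of 15000 nM to 100000 nM.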

Compound 3, half-maximal inhibitory concentration: 23500 nM
Compound 3: the middle estimate sits 2.1-fold (0.33 log units) above what was measured; the measured number falls inside the stated range.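

In this assay, the change from 3-(1H-pyrrol-1-yl)propyl to 4-(1H-imidazol-1-yl)butyl gives an at least 4.2-fold lower number from compound 1 to compound 3 (0.62 log units; beyond the scatter). Among the compounds shown here, this shows that the read-out responds to the side chain while the imide stays unsubstituted, which the earlier compounds could not show, as compound 2 differs from compound 1 in more than one place. The true size of the step stays unknown because compound 1 stands at a limit of the assay, not at a number: the limit of > 100000 nM in this assay, at which 1 of the 3 values shown sits.

The step changes the ring and the chain length together, so the compounds shown do not separate the two; 3-(1H-imidazol-1-yl)propyl or 4-(1H-pyrrol-1-yl)butyl would be needed for that. On these data alone, it also remains open how a primary amine at the end of the chain would read here.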